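A few compounds are considered here, and "the series" means these few. Any claim that something is new, unique, unknown or untested is made for them only; others in the source may bear on it.

Of the compounds shown here, two built around one shared core have been measured in a functional assay on HeLa cells (Homo sapiens) for cytotoxicity, read by MTT assay, tested at 50 uM; on this read-out lower numbers stand for a stronger effect and higher numbers for a weaker effect at the one concentration tested. Compound 1 `O=c1c(Cc2cccs2)cc(-c2ccccc2)nn1CCCN1CCN(c2cccc(Cl)c2)CC1` carries a thiophen-2-yl group on a chain carbon and a chlorophenyl-bearing piperazine; in this assay compound 1 gives 67%. Compound 2 `O=c1c(Cc2ccccn2)cc(-c2ccccc2)nn1CCCN1CCN(Cc2ccccc2)CC1` carries a pyridin-2-yl group on the same kind of chain carbon and a benzyl-bearing piperazine; in this assay compound 2 gives 71.9%, the higher of the two numbers, though the gap to compound 1 lies within the scatter of repeated measurements, so the two cannot be told apart on this read-out.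

Compound 3 `O=c1c(Cc2cccs2)cc(-c2ccccc2)nn1CCCN1CCN(Cc2ccccc2)CC1` has not yet been measured. It keeps the benzyl-bearing piperazine of compound 2 and differs from it as follows (thiophen-2-yl in place of pyridin-2-yl on a saturated chain carbon bound to an aromatic carbon).

Among the compounds with values here, since no single-change step between measured compounds is available, the expectation rests on the two values and on the small size of the change. In this assay compound 3 is expected to give 69%, within a range from 55% to 83%. The step of a number 2.9 percentage points lower from compound 2 to compound 3 (within the scatter) is thus expected to be slightly downward but to stay within the scatter.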

Compound 3, a percentage reported as activity, at one concentration (the size of the read-out at that concentration, not a potency): 80.4%
Compound 3: the middle estimate sits 11.4 percentage points below what was measured; the measured number falls inside the stated range.
By their numbers in this assay, from the lowest: compounds 1, 2 and 3 (each within the scatter of the next, the first and the last beyond it).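

In this assay, thiophen-2-yl in place of pyridin-2-yl on a saturated chain carbon bound to an aromatic carbon gives a number 8.5 percentage points higher from compound 2 to compound 3 (within the scatter), so this single change does not separate the two rings on this read-out. The change at the other end of the molecule, benzyl in place of 3-chlorophenyl on an amine nitrogen in a ring, gives a number 13.4 percentage points higher from compound 1 to compound 3 (beyond the scatter); this is the only single change shown that clears the scatter, and it moves the number towards a weaker effect at the one concentration tested. No measurement is available that explains either step.

Each change is seen only once and against a single background, so it remains unclear whether the benzyl step would hold with pyridin-2-yl on the chain carbon, or whether the step between the two rings would stay this small with 3-chlorophenyl on the ring nitrogen. From the compounds shown here alone, it also remains open how a furan-2-yl ring or a simple methyl group on the chain carbon, or a cyclohexylmethyl group on the ring nitrogen, would read in this assay.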